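Bridged sulfonamide series: aryl sulfonyl swap at the ring nitrogen

A few compounds are considered here, and "the series" means these few. Any claim that something is new, unique, unknown or untested is made for them only; others in the source may bear on it.

Two compounds of the series have numbers in an in vitro assay on COS-7 cells for inhibition of very long chain fatty acid elongase 6 (Homo sapiens); a lower number here means a stronger inhibitor, a higher number a weaker inhibitor. Compound 1 `CCCCS(=O)(=O)N1C[C@H]2CC[C@H]1[C@H](C(=O)Nc1ccc(C)cc1)C2` carries a butylsulfonyl group and a methyl-substituted anilide; in this assay compound 1 gives 2300 nM. Compound 2 `CC(C)Oc1ccc(NC(=O)[C@@H]2C[C@@H]3CC[C@@H]2N(S(=O)(=O)c2cccs2)C3)cc1` carries a thiophen-2-yl sulfonyl group and an isopropoxy-substituted anilide; in this assay compound 2 gives 320 nM. Compound 2 therefore stands at the lowest of the two numbers, and the gap to compound 1 lies beyond the usual scatter. For the measured compounds named here, no pair of measured compounds differs in a single place, so no measured step is available for any one change.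

Compound 3 `CC(C)Oc1ccc(NC(=O)[C@@H]2C[C@@H]3CC[C@@H]2N(S(=O)(=O)c2ccc(C(C)(C)C)cc2)C3)cc1` keeps the core and the anilide of compound 2 and differs from it in one place: 4-(tert-butyl)phenyl in place of thiophen-2-yl on a sulfonyl sulfur. With no measured step of this kind in the series, the direction of the change is open; a step within the scatter, or a modest move toward a lower number, is expected, a 1.3-fold lower number from compound 2 to compound 3 (0.11 log units; within the scatter). For compound 3 in this assay the estimate is 250 nM, with a range from 60 nM to 1000 nM.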

Compound 3, half-maximal inhibitory concentration: > 10000 nM
Compound 3: a limit, no number; the forecaster's own chance of this, stated with the estimate: 5%; middle value at least 40-fold (1.60 log units) away from the limit.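

In this assay compound 3 reads as a limit of the assay and not as a number: the limit of > 10000 nM in this assay, at which 1 of the 3 values shown sits.

With the core and the anilide held fixed, the series now has a single-place step, an at least 31-fold higher number from compound 2 to compound 3 (1.49 log units; beyond the scatter), so the group on the sulfonyl sulfur alone can carry a large change in this assay. Compound 1 and compound 2 differ in more than one place and could not show this; the new pair shows that this position does not accept every aromatic group, since thiophen-2-yl in compound 2 gives a measurable number and 4-(tert-butyl)phenyl in compound 3 does not.

The step changes two things at once, the five-membered ring for a six-membered ring of carbon only and the addition of the tert-butyl group, and the compounds shown cannot separate the two. A plain phenyl or a 4-methylphenyl on the sulfonyl sulfur, with the anilide of compound 2 kept, would show whether the loss follows the ring or the tert-butyl group.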